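Adding a Methoxy Group: From Compound 2 to Compound 3

The compounds below may be only part of what the source reports. "The series", "measured", "known", "first", "only" and "open" are said of these compounds alone.

Compound 1 `O=C(/C=C/c1ccc(O)c(O)c1)c1cc2ccoc2cc1O`: 18900 nM
Compound 2 `COc1ccc(/C=C/C(=O)c2cc3ccoc3cc2O)cc1OC`: 10800 nM

In an assay on isolated protein for inhibition of lysosomal alpha-glucosidase (Rattus norvegicus), read by spectrophotometry, with a stated time of 5 min (a higher number here means a weaker inhibitor, a lower number a stronger inhibitor), compound 2 gives 10800 nM, the lower of the two numbers; compound 1 gives 18900 nM, a gap within the scatter, so neither compound is called the stronger. Compound 3 `COc1cc(OC)c(OC)cc1/C=C/C(=O)c1cc2ccoc2cc1O` has not yet been measured. It differs from compound 2 by methoxy in place of hydrogen on an aromatic carbon. Going by the values given here, no step between measured compounds exists to lean on, so the expected step is a 1.2-fold lower number from compound 2 to compound 3 (0.08 log units; within the scatter), none beyond the scatter. Compound 3 is therefore estimated at 9000 nM, with a range from 3500 nM to 25000 nM.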

Compound 3, half-maximal inhibitory concentration: 13400 nM
For compound 3 the middle estimate is 1.5-fold (0.17 log units) below the measured one, within the range that was stated.
By their numbers in this assay, from the lowest: compounds 2, 3 and 1 (each within the scatter of the next).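

In this assay, methoxy in place of hydrogen on an aromatic carbon, ortho to a large group, gives a 1.2-fold higher number from compound 2 to compound 3 (0.09 log units; within the scatter). This is the first step at a single place among these compounds, and it shows that a third methoxy group at this position leaves compound 3 not distinguishable from compound 2. Nothing measured here bears on why that is so. The compounds shown leave open whether an amine or a carboxylic acid at this same position would give a step beyond the scatter.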